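Bromo for fluoro on the aryl ring of compound 3

The source may report more compounds than this note shows. Statements on the series, on what has been measured and on what is new or still open speak of the compounds shown alone.

Measured compounds in a functional assay on A549 cells (Homo sapiens) for cytotoxicity, read by MTT assay, with a stated time of 72 h; a higher number here means a weaker inhibitor, a lower number a stronger inhibitor:
compound 1, `CNC(=O)c1cc(Oc2ccc(C(=O)/C=C/c3ccc(F)cc3Cl)cc2)ccn1`: 21100 nM
compound 2, `CNC(=O)c1cc(Oc2ccc(C(=O)/C=C/c3ccc(C#N)cc3)cc2)ccn1`: 26400 nM
compound 3, `CNC(=O)c1cc(Oc2ccc(C(=O)/C=C/c3ccc(F)cc3)cc2)ccn1`: 18600 nM

All three share one core and differ only on the aryl ring at the far end of the double-bonded chain. Compound 3 sits within the scatter of both compound 1 and compound 2: the step of a 1.1-fold lower number from compound 1 to compound 3 (0.05 log units; within the scatter) and the step of a 1.4-fold lower number from compound 2 to compound 3 (0.15 log units; within the scatter) are each within the scatter, as is a 1.3-fold higher number from compound 1 to compound 2 (0.10 log units; within the scatter). No one of the three separates from the others in this assay.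

Compound 4, `CNC(=O)c1cc(Oc2ccc(C(=O)/C=C/c3ccc(Br)cc3)cc2)ccn1`, is the next member. Its difference from compound 3 is bromo in place of fluoro on an aromatic carbon.

For the measured compounds named here, two measured steps bear on this change, both at the same ring. The exchange of cyano for fluoro at that position, a 1.4-fold lower number from compound 2 to compound 3 (0.15 log units; within the scatter), and the removal of chloro from the ring, a 1.1-fold lower number from compound 1 to compound 3 (0.05 log units; within the scatter), each stayed within the scatter. The replacement of one halogen by another at the same position is expected to behave the same way, so no step beyond the scatter is expected for a 1.0-fold lower number from compound 3 to compound 4 (0.01 log units; within the scatter).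

Compound 4 is therefore estimated at 18000 nM in this assay, with a range from 9000 nM to 36000 nM.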

Compound 4, half-maximal inhibitory concentration: > 50000 nM
Compound 4: a limit, no number (the forecaster's own chance of this, stated with the estimate: 5%); at least 2.7-fold (0.44 log units) between middle value and limit.
By their numbers in this assay, from the lowest: compounds 3, 1 and 2 (each within the scatter of the next). At a limit, above all of these: compound 4.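

Compounds 1, 2 and 3 showed this aromatic carbon, para to a large group, as tolerant of exchange, but in this assay the group there does matter: an at least 2.6-fold higher number from compound 3 to compound 4 (0.42 log units; beyond the scatter), so one halogen in place of another separates two compounds that differ in one atom. The separation also holds against the 2-chloro-4-fluorophenyl end group, an at least 2.3-fold higher number from compound 1 to compound 4 (0.37 log units; beyond the scatter), whereas against the 4-cyanophenyl end group, an at least 1.8-fold higher number from compound 2 to compound 4 (0.27 log units; that floor lies within the scatter), so compound 4 cannot yet be set apart from compound 2 by this floor. Compound 4 stands at a limit and not at a number, which makes each of these steps a minimum and leaves its true size unknown: the limit of > 50000 nM in this assay, at which 1 of the 4 values shown sits.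

On these data alone, what remains open is how far the number for compound 4 lies past that limit, and whether the break belongs to bromo alone or to any halogen heavier than fluoro, which a chloro or iodo on this same carbon would settle. A methoxy or an amine at this carbon would show whether groups other than halogens and nitrile also leave the range held by compounds 1, 2 and 3.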